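The source may hold more compounds than are shown below. What is called first, only, known or untested is meant among the compounds shown, and "the series" means these compounds.

Working notes, antiproliferative series. The read-out throughout is a functional assay on DLD-1 cells (Homo sapiens) for antiproliferative activity, read by CellTiter-Glo, with a stated time of 72 h; on this read-out lower numbers stand for stronger inhibition and higher numbers for weaker inhibition. Compound 1 `CC1CCN(C2CCN(S(=O)(=O)c3cccc(C(F)(F)F)c3)CC2)CC1` carries a trifluoromethyl on an aromatic carbon of the shared core. In this assay compound 1 returns only a limit, > 5000 nM, so no number stands for it, which is the position of one of the two values shown (the limit of > 5000 nM in this assay, at which 1 of the 2 values shown sits). Compound 2 `CC1CCCN(C2CCN(S(=O)(=O)c3ccc(OC(F)F)cc3)CC2)C1` gives 105 nM in this assay. Compound 3 `CC1CCN(C2CCN(S(=O)(=O)c3cccc(-c4ccccc4C(F)(F)F)c3)CC2)CC1` is the untested member. It differs from compound 1 by 2-(trifluoromethyl)phenyl in place of trifluoromethyl on an aromatic carbon, on an aromatic carbon of a six-membered aromatic ring of carbon only, meta to a large group. Within the data shown here, no step between measured compounds is known, so the direction of this change rests on nothing measured; a modest move into the measurable range in this assay is expected, of uncertain size. Compound 3 is therefore estimated at 3000 nM, within 700 nM to 12000 nM. The expected step is an at least 1.6-fold lower number from compound 1 to compound 3 (0.22 log units; that floor lies within the scatter).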

Compound 3, half-maximal inhibitory concentration: 10 nM
Estimate against measurement, compound 3: 300-fold (2.48 log units) above; the whole stated range lies above it.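

In this assay, 2-(trifluoromethyl)phenyl in place of trifluoromethyl on an aromatic carbon, meta to a large group, gives an at least 500-fold lower number from compound 1 to compound 3 (2.69 log units; beyond the scatter). Among these compounds, this is the first readable evidence that the group at this position can decide the read-out, and that a six-membered aromatic ring of carbon only is accepted there with a number well inside the measurable range. The size of the step is a bound and not an exact difference, since compound 1 stands only at a limit: the limit of > 5000 nM in this assay, at which 1 of the 3 values shown sits.

From the compounds shown here alone, what a plain phenyl, or an aromatic ring bearing an amine or a carboxylic acid, would give at this carbon stays open, so the shares of the ring and of its trifluoromethyl cannot be separated. Compound 2 differs from compound 3 in more than one place and gives no reading on this change.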